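This account rests on a few compounds, and the source may have more. Where it says the series, first, only, none or still open, it means among the compounds named here.

Measured compounds:
compound 1 `COC(=O)/C(=C/c1ccccc1)CN1C(=O)[C@@H](OC)[C@H]1c1cccc(F)c1` — 38500 nM
compound 2 `COC(=O)/C(=C/c1ccccc1)CN1C(=O)[C@@H](OC)[C@H]1c1ccccc1` — "not toxic" (no number reported)
compound 3 `COC(=O)/C(=C/c1ccccc1)CN1C(=O)[C@@H](OC)[C@H]1c1cccc([N+](=O)[O-])c1` — "not toxic" (no number reported)

In an ADME assay on cells (Epithelial cell, Homo sapiens) for antiproliferative activity, read by MTT assay, with a stated time of 48 h (on this read-out higher numbers stand for weaker inhibition and lower numbers for stronger inhibition), compound 1 gives 38500 nM, a high value that marks weak inhibition. Compound 2 is recorded in this assay as "not toxic" (no number reported), without a number. Compound 3 stands the same way: in this assay compound 3 is reported as "not toxic" (no number reported), and no single number is attached to it. On the numbers shown, then, compound 3 has no measured value of its own, and it shares this position with compound 2, so only compound 1 puts a figure on the series.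

The next compound, compound 4 `COC(=O)/C(=C/c1ccccc1)CN1C(=O)[C@@H](OC)[C@H]1c1ccc(OC)cc1`, differs from compound 3 in one place: 4-methoxyphenyl in place of 3-nitrophenyl on a saturated ring carbon. Within the data shown here, with no measured step available between compounds that differ in one place, the expected size of the change in this assay must be read from the three measured compounds, all of which point to weak or undetectable inhibition. The expectation is therefore no step beyond the scatter, and a real chance that compound 4 is again reported without a number. Compound 4 is estimated to give 50000 nM in this assay, within a range of 15000 nM to 200000 nM.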

Compound 4, half-maximal inhibitory concentration: "not toxic" (no number reported)
Compound 4: no number reported; there is nothing to compare the estimate with.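

Compound 4, like compound 3, carries no number in this assay, so no step can be read between compound 3 and compound 4. The compounds shown leave open how far 4-methoxyphenyl and 3-nitrophenyl differ in their effect on inhibition in this assay. Nothing given here bears on this result.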